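From a Cyclohexyl Carbamate to a Dimethyl Carbamate

The compounds below may be only part of what the source reports. "The series", "measured", "known", "first", "only" and "open" are said of these compounds alone.

Two measured compounds share one core and differ only in the group on an amide-type nitrogen. Compound 1 `CCNC(=O)OC[C@H]1OC(n2cnc3c(NC4CCOC4)ncnc32)[C@H](O)[C@@H]1O` carries an ethyl group there, and in an assay on DDT1 cells (Cricetulus griseus) for binding affinity to adenosine receptor A1 (Homo sapiens), read by radioligand binding (on this read-out lower numbers stand for stronger inhibition and higher numbers for weaker inhibition), compound 1 gives 167 nM. Compound 2 `O=C(NC1CCCCC1)OC[C@H]1OC(n2cnc3c(NC4CCOC4)ncnc32)[C@H](O)[C@@H]1O` carries a cyclohexyl group instead, and in this assay compound 2 gives 584 nM. Within the data shown here, that single exchange produced a 3.5-fold higher number from compound 1 to compound 2 (0.54 log units; beyond the scatter), so compound 2 stands with the highest of the two numbers known so far, with compound 1 as its nearest neighbour.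

Compound 3 `CN(C)C(=O)OC[C@H]1OC(n2cnc3c(NC4CCOC4)ncnc32)[C@H](O)[C@@H]1O` has not yet been measured in this assay. It is reached from compound 2 by dimethylamino in place of cyclohexylamino on a carbonyl carbon. Among the measured compounds shown here, the one measured step that bears on this change is a 3.5-fold higher number from compound 1 to compound 2 (0.54 log units; beyond the scatter), which shows that the larger cyclohexyl group went with a higher number than the small ethyl group. For the measured compounds named here, for compound 3 the return to a small group is therefore expected to bring a modest fall, a 2.3-fold lower number from compound 2 to compound 3 (0.37 log units; beyond the scatter), although the loss of the hydrogen-bond donor has no measured precedent here. Compound 3 is estimated at 250 nM in this assay, with a likely range from 80 nM to 800 nM.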

Compound 3, inhibition constant: 238 nM
The estimate for compound 3 lay 1.1-fold (0.02 log units) above the measured number; low and high end bracket the measured number.
By their numbers in this assay, from the lowest: compounds 1 and 3 (each within the scatter of the next); then compound 2.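

Exchanging cyclohexylamino for dimethylamino on the carbonyl carbon gives a 2.5-fold lower number from compound 2 to compound 3 (0.39 log units; beyond the scatter) in this assay, so a second small group now stands apart from cyclohexylamino, as ethylamino already did. The exchange of ethylamino for dimethylamino, which removes the amide hydrogen, gives a 1.4-fold higher number from compound 1 to compound 3 (0.15 log units; within the scatter) and so leaves no difference that can be read between these two groups at this position, while the step from compound 2 to compound 3 changes the ring, the size and the hydrogen-bond donor all at once. No measurement at hand gives a reason for these differences.

With only these three groups, the effect of the ring cannot be separated from that of the amide hydrogen, and a pyrrolidine ring joined through its nitrogen to the carbonyl carbon, which has a ring but no such hydrogen, would bear directly on that question. Nor do the compounds shown tell how far the chain can grow before the number rises, as a butyl chain on the same nitrogen could show.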